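From cyclobutylmethyl to 3-methoxypropyl on the ring amine

The source may hold more compounds than are shown below. What is called first, only, known or untested is meant among the compounds shown, and "the series" means these compounds.

In a functional assay (strain AB) with Danio rerio as the target, read by microscopy, with a stated time of 1 h (a higher number here means that more compound is needed for the effect, a lower number that less compound is needed), compound 1 `CCN1CCc2c(sc(NC=O)c2C(N)=O)C1` reads > 25000 nM and this is a limit of the assay, not a number. Compound 3 `CCN1CCc2c(sc(NC(=O)C3(c4ccc(Cl)cc4)CC3)c2C(N)=O)C1` reads > 25000 nM and this too is a limit. Compound 2 `NC(=O)c1c(NC(=O)Nc2ccc(Cl)cc2)sc2c1CCN(CC1CCC1)C2` gives 1360 nM and is the only one of the three with a true number, so it has no measured neighbour to be ranked against. Two of the three values sit at a single limit (the limit of > 25000 nM in this assay, at which 2 of the 3 values shown sit).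

The next compound to be read is compound 4 `COCCCN1CCc2c(sc(NC(=O)Nc3ccc(Cl)cc3)c2C(N)=O)C1` and it keeps the rest of compound 2 unchanged. It carries 2-methoxyethyl in place of cyclobutyl on a saturated chain carbon bound to an amine nitrogen in a ring and, cut one bond further out, this reads cyclobutylmethyl to 3-methoxypropyl.

Going by the values given here, no measured step covers this change, so the expectation rests on compound 2 at 1360 nM alone. A moderate move toward a higher number in this assay is expected, with a step beyond the scatter more likely than none, and the estimated size is a 1.8-fold higher number from compound 2 to compound 4 (0.26 log units; within the scatter) as a rough figure. The estimate for compound 4 is 2500 nM with an expected range from 700 nM to 9000 nM as the reading to test.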

Compound 4, half-maximal effective concentration: 2400 nM
Estimate against measurement, compound 4: 1.0-fold (0.02 log units) above, within the range that was stated.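

In this assay, the substituent on the ring amine now has its first measured step: a 1.8-fold higher number from compound 2 to compound 4 (0.25 log units; within the scatter). This position therefore accepts an open chain carrying an oxygen, 2-methoxyethyl, in place of the all-carbon ring of cyclobutyl, on a saturated chain carbon bound to an amine nitrogen in a ring, with the reading remaining a true number and no change beyond the scatter, something compound 2 alone could not show. The two groups have the same count of heavy atoms, yet they differ in ring, oxygen and hydrogen-bond acceptor count, and nothing measured here gives a reason for the size of the step.

With both the ring and the oxygen exchanged in a single step, the contribution of each remains unseparated, and a plain butyl chain or a methoxy-bearing ring on the same carbon would be needed to tell them apart. From the compounds shown here alone, how far this position stretches also remains open, including whether a longer chain, a terminal amine or a carboxylic acid at the end of the chain would keep the reading in the range of compound 2 and compound 4.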